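The source may report more compounds than this note shows. Statements on the series, on what has been measured and on what is new or still open speak of the compounds shown alone.

Three close relatives of one shared core have been tested, and a fourth still awaits its number. Compound 1 `COc1cccc(Nc2nc3c(c(Oc4cccc(NC(=O)C=C(C)C)c4)n2)CSCC3)c1` is the starting point; in a functional assay on A549 cells (Homo sapiens) for antiproliferative activity, read by MTT assay, with a stated time of 72 h (on this read-out higher numbers stand for weaker inhibition and lower numbers for stronger inhibition), compound 1 gives 19800 nM. Compound 2 `COc1cccc(Nc2nc3c(c(Oc4cccc(NC(=O)/C=C/C(C)C)c4)n2)CSCC3)c1` differs from it in a single place, (3-methylbut-1-en-1-yl in place of 2-methylprop-1-en-1-yl on a carbonyl carbon), and in this assay compound 2 gives 25300 nM, so that a 1.3-fold higher number from compound 1 to compound 2 (0.11 log units; within the scatter). Compound 3 `COc1ccc(Nc2nc3c(c(Oc4cccc(NC(=O)C=C(C)C)c4)n2)CSCC3)cc1` keeps the amide of compound 1 but has a different core, (4-methoxyphenyl in place of 3-methoxyphenyl on a nitrogen on an aromatic ring); in this assay compound 3 gives 26900 nM, and a 1.4-fold higher number from compound 1 to compound 3 (0.13 log units; within the scatter). Compound 4 `COc1ccc(Nc2nc3c(c(Oc4cccc(NC(=O)/C=C/C(C)C)c4)n2)CSCC3)cc1` has not yet been measured. It stands to compound 3 exactly as compound 2 stands to compound 1: the change is 3-methylbut-1-en-1-yl in place of 2-methylprop-1-en-1-yl on a carbonyl carbon, made on a carbonyl carbon in both pairs, so it is the same change, seen twice among these four compounds. A similarly small step is expected on the new core, a 1.2-fold higher number from compound 3 to compound 4 (0.09 log units; within the scatter), because a 1.3-fold higher number from compound 1 to compound 2 (0.11 log units; within the scatter) lies within the scatter and nothing here suggests the core alters that. For compound 4 in this assay a value near 33000 nM is estimated, expected to fall between 17000 nM and 66000 nM.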

Compound 4, half-maximal inhibitory concentration: 25900 nM
Estimate against measurement, compound 4: 1.3-fold (0.11 log units) above, within the range that was stated.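

In this assay, placing 3-methylbut-1-en-1-yl instead of 2-methylprop-1-en-1-yl on the carbonyl carbon again makes little difference on the second core, with a 1.0-fold lower number from compound 3 to compound 4 (0.02 log units; within the scatter), and this agrees with the earlier reading of the same change: the same change on two cores in this assay, a 1.3-fold higher number (0.11 log units; within the scatter) from compound 1 to compound 2 and a 1.0-fold lower number (0.02 log units; within the scatter) from compound 3 to compound 4, 1.3-fold (0.12 log units) apart, within the scatter of two such steps

The other change, 4-methoxyphenyl in place of 3-methoxyphenyl on a nitrogen on an aromatic ring, behaves the same way, with a 1.0-fold higher number from compound 2 to compound 4 (0.01 log units; within the scatter), and it also agrees with its earlier reading: the same change on two cores in this assay, a 1.4-fold higher number (0.13 log units; within the scatter) from compound 1 to compound 3 and a 1.0-fold higher number (0.01 log units; within the scatter) from compound 2 to compound 4, 1.3-fold (0.12 log units) apart, within the scatter of two such steps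

So among these four compounds each change carries from one core to the other as a step within the scatter, but this shows only that both changes do little here, not that a change with a large effect would carry over as faithfully.

What the compounds shown leave open is whether any other group on the carbonyl carbon, such as a longer chain or one ending in an amine, would give a step beyond the scatter. Going by these compounds, it is also open whether a group other than methoxy on the phenyl ring, such as a carboxylic acid, would do so.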